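Series notes: aryl swap at the pendant ring, compound 1 to compound 4

A few compounds are considered here, and "the series" means these few. Any claim that something is new, unique, unknown or untested is made for them only; others in the source may bear on it.

Compound 1 `Cc1ccccc1-n1nc(C)c2c1NC(=O)[C@H](C)S[C@@H]2c1ccc(/C=C/c2ccccc2)cc1` is the starting point for this step. In an assay on isolated protein for agonist activity at Bile acid receptor (Homo sapiens), read by AlphaScreen, with a stated time of 30 min (a higher number here means that more compound is needed for the effect, a lower number that less compound is needed), compound 1 gives "not active" (no number reported), so no number places it against the others; it stands apart from the measured pair rather than at any point on the scale. Compound 2 `Cc1nn(-c2ccccc2C(F)(F)F)c2c1C(c1ccc(Oc3ccccc3)cc1)SC(C)C(=O)N2` gives 2000 nM in this assay, and compound 3 `Cc1nn(-c2ccccc2Cl)c2c1C(c1ccc(Oc3ccccc3)cc1)SC(C)C(=O)N2` gives 2700 nM. For the measured compounds named here, the only measured step, a 1.4-fold higher number from compound 2 to compound 3 (0.13 log units; within the scatter), concerns a different position from the one changed here and says nothing about the pendant ring.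

Compound 4 `Cc1ccccc1-n1nc(C)c2c1NC(=O)[C@H](C)S[C@@H]2c1ccc(-c2cc3ccccc3o2)cc1` differs from compound 1 by 1-benzofuran-2-yl in place of 2-phenylethenyl on an aromatic carbon. Going by the values given here, no measured step touches this change, so nothing fixes its direction or size. The two compounds with a number in this assay, compound 2 and compound 3, show what the shared core can reach with a different pendant group, and only that.

Compound 4 is therefore estimated at 3000 nM in this assay, with a wide range from 500 nM to 20000 nM, and a real chance that, like compound 1, only inactivity is reported.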

Compound 4, half-maximal effective concentration: 1500 nM
The estimate for compound 4 lay 2.0-fold (0.30 log units) above the measured number; the range from low to high includes it.
By their numbers in this assay, from the lowest: compounds 4, 2 and 3 (each within the scatter of the next).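

In this assay compound 1 gives "not active" (no number reported) and compound 4 gives 1500 nM so no step can be read between them. The compounds shown leave open how 1-benzofuran-2-yl and 2-phenylethenyl compare numerically on the shared core. No evidence shown bears on this result.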